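This account rests on a few compounds, and the source may have more. Where it says the series, first, only, none or still open, it means among the compounds named here.

Working notes on the series in a functional assay on A549 cells (Homo sapiens) for cytotoxicity, read by MTT assay, with a stated time of 48 h; a higher number here means a weaker inhibitor, a lower number a stronger inhibitor. Compound 1 (`COc1cc([C@@H]2C[C@@]2(CO)C(=O)Nc2ccccc2)cc(OC)c1OC`) gives 43200 nM, compound 2 (`CCOC(=O)[C@]1(C(=O)Nc2ccccc2)C[C@@H]1c1cc(OC)c(OC)c(OC)c1`) gives 21300 nM, and compound 3 (`COc1cc([C@H]2C[C@]2(CO)C(=O)NCc2ccc(C)cc2)cc(OC)c1OC`) gives 60700 nM. Compound 3 stands within the scatter of compound 1, while its number is higher than that of compound 2 by a gap beyond the scatter.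

The next compound, compound 4 (`COc1cc([C@H]2C[C@]2(CO)C(=O)Nc2ccccc2)cc(OC)c1OC`), has phenyl in place of 4-methylbenzyl on an amide-type nitrogen. Going by the values given here, no measured pair isolates this change, so any expectation rests on indirect evidence. The anilino group of compound 4 is also present in compound 1, at 43200 nM, and that value does not separate from the value of compound 3. No step beyond the scatter is therefore expected, with a slight lean towards a lower number. The estimated change is a 1.4-fold lower number from compound 3 to compound 4 (0.16 log units; within the scatter), which stays within the scatter. Compound 4 is expected at 42000 nM, with an estimated range of 19000 nM to 90000 nM.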

Compound 4, half-maximal inhibitory concentration: > 100000 nM
Compound 4 ended at the assay's limit (the forecaster's own chance of this, stated with the estimate: 10%); at least 2.3-fold (0.37 log units) between middle value and limit.
By their numbers in this assay, from the lowest: compound 2; then compounds 1 and 3 (each within the scatter of the next). At a limit, above all of these: compound 4.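

In this assay compound 4 gives > 100000 nM, which is a limit of the assay and not a number. The series now holds a mirror-image pair, and an at least 2.3-fold higher number from compound 1 to compound 4 (0.36 log units; beyond the scatter) shows that configuration alone can move the number beyond the scatter in this assay, a separation that can be read directly here: the fact that compounds 1 and 4 differ only in the configuration as drawn With hydroxymethyl in place of ethoxycarbonyl on a saturated ring carbon, the step is an at least 4.6-fold higher number from compound 2 to compound 4 (0.67 log units; beyond the scatter), whereas phenyl in place of 4-methylbenzyl on the amide-type nitrogen gives an at least 1.6-fold higher number from compound 3 to compound 4 (0.21 log units; that floor lies within the scatter), so that change remains unresolved.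

Whether the configuration effect carries over to the 4-methylbenzyl amide remains open, as compound 3 has no mirror-image partner among the compounds shown. Also open, going by these compounds, is how a carboxylic acid or a primary amine would read at the saturated ring carbon that carries hydroxymethyl.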